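The source may report more compounds than this note shows. Statements on the series, on what has been measured and on what is new or still open speak of the compounds shown alone.

Of the compounds shown here, three sharing one core have been measured in a functional assay on HeLa cells (Homo sapiens) for antiproliferative activity, read by CCK-8 assay, with a stated time of 48 h; a lower number here means a stronger inhibitor, a higher number a weaker inhibitor. Compound 1 `Cc1ccc(CSc2n[nH]c(-n3[se]c4ccccc4c3=O)n2)cc1` gives 34800 nM in this assay. Compound 2 `O=c1c2ccccc2[se]n1-c1nc(SCc2ccc(Cl)cc2)n[nH]1` gives 40900 nM in this assay. Compound 3 `O=c1c2ccccc2[se]n1-c1nc(SCc2ccccc2)n[nH]1` reaches only the limit of this assay, reported as > 50000 nM, which is a limit and not a number (the limit of > 50000 nM in this assay, at which 1 of the 3 values shown sits). The steps among the three are a 1.2-fold higher number from compound 1 to compound 2 (0.07 log units; within the scatter), an at least 1.4-fold higher number from compound 1 to compound 3 (0.15 log units; that floor lies within the scatter) and an at least 1.2-fold higher number from compound 2 to compound 3 (0.08 log units; that floor lies within the scatter), none of them beyond the scatter. Compound 3 thus stands at the limit, on a par with the other two as far as the numbers can tell.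

Compound 4 `CCCCSc1n[nH]c(-n2[se]c3ccccc3c2=O)n1` has not been measured in this assay. It differs from compound 3 in one place: propyl in place of phenyl on a saturated chain carbon bound to a sulfur. Within the data shown here, no measured step bears directly on this change; the three measured steps all concern a substituent on the phenyl that leaves, and all stay within the scatter. Starting from a limit and with no step to lean on, the step expected is a step that the limit leaves unreadable from compound 3 to compound 4, that is, none beyond the scatter. Compound 4 is therefore estimated at 60000 nM, between 30000 nM and 120000 nM, most likely again reported as a limit.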

Compound 4, half-maximal inhibitory concentration: 32900 nM
Estimate against measurement, compound 4: 1.8-fold (0.26 log units) above; the range from low to high includes it.
By their numbers in this assay, from the lowest: compounds 4, 1 and 2 (each within the scatter of the next). At a limit, above all of these: compound 3.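

Exchanging the phenyl for propyl on the saturated chain carbon bound to a sulfur is the first change shown that removes the aromatic ring rather than altering a substituent on it, and in this assay it gives an at least 1.5-fold lower number from compound 3 to compound 4 (0.18 log units; that floor lies within the scatter). The value of compound 3 remains a limit and not a number: the limit of > 50000 nM in this assay, at which 1 of the 4 values shown sits. Against the two ring-bearing compounds with a number, the chain gives a 1.2-fold lower number from compound 2 to compound 4 (0.09 log units; within the scatter) and a 1.1-fold lower number from compound 1 to compound 4 (0.02 log units; within the scatter), so among these compounds a ring at this place is not needed to keep the activity at this level.

No step among the four compounds is shown to lie beyond the scatter, so it remains open whether this position can shift the activity at all. A longer chain, an amine or a carboxylic acid in place of the propyl would be needed to test that.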